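The compounds below may be only part of what the source reports. "The series", "measured", "known", "first", "only" and "open" are said of these compounds alone.

Compound 1 `CCNC(=O)[C@H]1O[C@@H](n2cnc3c(NNC(=O)c4ccccc4)ncnc32)[C@H](O)[C@@H]1O` gives > 5000 nM in a functional assay on CHO cells for activation of adenosine receptor A2b (Homo sapiens), read by cAMP accumulation; a higher number here means that more compound is needed for the effect, a lower number that less compound is needed; this value is a limit of the assay, not a number.
Compound 2 `CCNC(=O)[C@H]1O[C@@H](n2cnc3c(NNC(=O)c4ccc(C)o4)ncnc32)[C@H](O)[C@@H]1O` gives 227 nM in this assay.
Compound 3 `CCNC(=O)[C@H]1O[C@@H](n2cnc3c(NNC(=O)c4cccs4)nc(Cl)nc32)[C@H](O)[C@@H]1O` gives 200 nM in this assay.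

Of the two compounds with a number, compound 3 and compound 2 lie within the scatter of each other, so neither can be called the more potent. Compound 1 sits at a limit, (the limit of > 5000 nM in this assay, at which 1 of the 3 values shown sits), and so offers no number to compare.

Compound 4 `CCNC(=O)[C@H]1O[C@@H](n2cnc3c(NNC(=O)c4cc(C)on4)nc(Cl)nc32)[C@H](O)[C@@H]1O` has not yet been measured. It differs from compound 3 in one place: 5-methyl-1,2-oxazol-3-yl in place of thiophen-2-yl on a carbonyl carbon. Among the compounds with values here, the only measured step, an at least 22-fold lower number from compound 1 to compound 2 (1.34 log units; beyond the scatter), also exchanged the ring on that carbonyl carbon, and it was large, from a limit to a clear number. The change from compound 3 to compound 4, however, swaps one five-membered ring for another, and compound 2 and compound 3, which carry two different five-membered rings at that position, give values within the scatter of each other. The expected step of a 1.8-fold higher number from compound 3 to compound 4 (0.24 log units; within the scatter) is therefore small, in either direction. Compound 4 is estimated at 350 nM, with a range from 100 nM to 2000 nM.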

Compound 4, half-maximal effective concentration: > 5000 nM
Compound 4: only a limit was reported; the forecaster's own chance of this, stated with the estimate: 12%; middle value at least 14-fold (1.15 log units) from the limit.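

On this carbonyl carbon, being a five-membered aromatic ring does not by itself preserve activity: 5-methyl-1,2-oxazol-3-yl in place of thiophen-2-yl gives an at least 25-fold higher number from compound 3 to compound 4 (1.39 log units; beyond the scatter) in this assay. Compound 4 gives > 5000 nM, which is a limit of the assay and not a number, so the full size of this loss cannot be read. The earlier step, from a phenyl to a 5-methylfuran-2-yl, could have been read as a contrast between a six-membered and a five-membered ring, but this step shows that the position also tells two five-membered aromatic rings apart, and the limit is now shared by two compounds: the limit of > 5000 nM in this assay, at which 2 of the 4 values shown sit.

The change alters several things at once, the hetero atoms of the ring, the methyl group and the point at which the ring is attached, and the compounds shown do not separate them. On these data alone, it remains open whether a 5-methylthiophen-2-yl or an unsubstituted 1,2-oxazol-3-yl on the core of compound 3 would give a measurable value in this assay, and how a pyridin-2-yl ring would behave there.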